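Urea aryl swap in an oxadiazole nicotinamide series

The source may report more compounds than this note shows. Statements on the series, on what has been measured and on what is new or still open speak of the compounds shown alone.

Measured so far:
compound 1, `CC(=O)Nc1ccc(S(=O)(=O)Nc2cccc(-c3nc(-c4ccc(NC(=O)c5cccnc5)c(Cl)c4)no3)c2)cc1`, 4500 nM
compound 2, `CCNC(=O)Nc1ccc(S(=O)(=O)Nc2cccc(-c3nc(-c4ccc(NC(=O)c5cccnc5)cc4Cl)no3)c2)cc1`, 3100 nM
compound 3, `O=C(Nc1cccc(-c2nc(-c3ccc(NC(=O)c4cccnc4)cc3Cl)no2)c1)Nc1ccc(Cl)c(C(F)(F)F)c1`, 1900 nM

In a functional assay on MDA-MB-231 cells (Homo sapiens) for antiproliferative activity, read by MTT assay, with a stated time of 72 h (a lower number here means a stronger inhibitor, a higher number a weaker inhibitor), compound 3 gives the lowest of the three numbers. Its gap to compound 2 lies within the scatter, so no order between the two can be claimed; its gap to compound 1 lies beyond it.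

Compound 4, `CC(=O)Nc1ccc(NC(=O)Nc2cccc(-c3nc(-c4ccc(NC(=O)c5cccnc5)cc4Cl)no3)c2)cc1`, differs from compound 3 in one place: 4-acetamidophenyl in place of 4-chloro-3-(trifluoromethyl)phenyl on an amide-type nitrogen. Among the compounds with values here, no step between measured compounds isolates this change, so the expectation rests on the other urea, compound 2, and on compound 1, which also carries the 4-acetamidophenyl group. Both sit above compound 3. A modest rise in the number is therefore expected, a 1.8-fold higher number from compound 3 to compound 4 (0.27 log units; within the scatter), with compound 4 estimated at 3500 nM, between 1500 nM and 8000 nM.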

Compound 4, half-maximal inhibitory concentration: > 10000 nM
Compound 4: a limit, no number; the forecaster's own chance of this, stated with the estimate: 5%; middle value at least 2.8-fold (0.45 log units) from the limit.
By their numbers in this assay, from the lowest: compounds 3, 2 and 1 (each within the scatter of the next, the first and the last beyond it). At a limit, above all of these: compound 4.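

Putting 4-acetamidophenyl in place of 4-chloro-3-(trifluoromethyl)phenyl on the amide-type nitrogen gives an at least 5.2-fold higher number from compound 3 to compound 4 (0.72 log units; beyond the scatter), so this assay is sensitive to the aryl group at this urea position. Compound 4 reads > 10000 nM, which is a limit of the assay and not a number. The full size of the step therefore cannot be read: the limit of > 10000 nM in this assay, at which 1 of the 4 values shown sits.

The compounds shown leave open whether the acetamido group or the loss of chlorine and trifluoromethyl accounts for the step. A plain phenyl, or a phenyl carrying only chlorine or only trifluoromethyl, on the same nitrogen would separate these.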